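A few compounds are considered here, and "the series" means these few. Any claim that something is new, unique, unknown or untested is made for them only; others in the source may bear on it.

Compound 1 `CC1CC/C(=N\Nc2ccccc2F)c2ncc(C(=O)O)c(=O)n21` gives > 1000 umol/kg in a functional assay on the whole organism for inhibition, with Rattus norvegicus as the target; a lower number here means that less compound is needed, a higher number that more compound is needed for the effect.
Compound 2 `CC1CC/C(=N\Nc2ccccc2I)c2ncc(C(=O)O)c(=O)n21` gives > 1000 umol/kg.
Compound 3 `CCOc1cccc(N/N=C2\CCC(C)n3c2ncc(C(=O)O)c3=O)c1` gives > 1000 umol/kg.

Each of these three values is a limit of the assay, not a measured number. All of them sit at the limit of > 1000 umol/kg in this assay, at which 3 of the 3 values shown sit, so no compound in this set has yet shown a readable dose. Within the data shown here, the only measured step, a step that the two limits leave unreadable from compound 1 to compound 2, joins two such limits and therefore tells nothing about its size or direction. Compound 3 stands in the same position: its result is only a limit, with no number to compare against.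

Compound 4 `Cc1cccc(N/N=C2\CCC(C)n3c2ncc(C(=O)O)c3=O)c1` differs from compound 3 by methyl in place of ethoxy on an aromatic carbon. Among the measured compounds shown here, no measured step bears on this change, and the single step that exists cannot be read, so there is no basis for expecting a move in either direction beyond the scatter. Compound 4 is therefore expected to give 2000 umol/kg, with a range from 500 umol/kg to 10000 umol/kg, most likely again as a limit. This corresponds to an expected step that the limit leaves unreadable from compound 3 to compound 4.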

Compound 4, dose for 50% inhibition: 72.5 umol/kg
Compound 4: middle estimate off by 28-fold (1.44 log units), on the high side; the measured number lies below the stated range.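

In this assay, compound 4 gives the first readable dose in this set, which shows that the group on this aromatic carbon, meta to a large group, can change the result: methyl in place of ethoxy gives an at least 13-fold lower number from compound 3 to compound 4 (1.13 log units; beyond the scatter). The replacement of the whole aryl group points the same way, with an at least 13-fold lower number from compound 2 to compound 4 (1.13 log units; beyond the scatter) and an at least 13-fold lower number from compound 1 to compound 4 (1.13 log units; beyond the scatter), and each of these three sizes is only a minimum. Compound 4 alone has a measured number, while the other compounds share one limit: the limit of > 1000 umol/kg in this assay, at which 3 of the 4 values shown sit.

The step from compound 1 to compound 2 still cannot be read, as both of its ends are limits. On these data alone, it remains open whether a chloro group, a propyl chain or a bare hydrogen at this place would also give a readable dose, and whether methyl on another ring carbon would do the same.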